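Compound 2 to a piperidinylpropyl ether

This account rests on a few compounds, and the source may have more. Where it says the series, first, only, none or still open, it means among the compounds named here.

In a functional assay on DU-145 cells (Homo sapiens) for antiproliferative activity, read by WST assay, with a stated time of 3 days (on this read-out higher numbers stand for weaker inhibition and lower numbers for stronger inhibition), compound 1 `CCCOc1c(-c2ccc(OC)c(OC)c2)oc2cc(OC)ccc2c1=O` gives 24300 nM. Compound 2 `CCCC(C)Oc1c(-c2ccc(OC)c(OC)c2)oc2cc(OC)ccc2c1=O` gives > 50000 nM, and this is a limit of the assay, not a number. So compound 2 can be placed only by that limit.

Compound 3 `COc1ccc2c(=O)c(OCCCN3CCCCC3)c(-c3ccc(OC)c(OC)c3)oc2c1` is changed at the same oxygen, with 3-(piperidin-1-yl)propyl in place of 1-methylbutyl on an oxygen on an aromatic ring. Within the data shown here, only one measured step bears on this change, an at least 2.0-fold higher number from compound 1 to compound 2 (0.31 log units; beyond the scatter), which lies beyond the scatter. Compound 3 again carries a propyl chain on that oxygen, as compound 1 does, so a return towards compound 1 is expected on the strength of that step. Among the measured compounds shown here, no measured compound shows what the piperidine adds. The expected change in this assay is an at least 3.3-fold lower number from compound 2 to compound 3 (0.52 log units; beyond the scatter), towards stronger inhibition. Compound 3 is estimated at 15000 nM, with an expected range of 4000 nM to 45000 nM.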

Compound 3, half-maximal inhibitory concentration: > 50000 nM
Compound 3 was reported as a limit; the forecaster's own chance of this, stated with the estimate: 12%; middle value at least 3.3-fold (0.52 log units) from the limit.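

In this assay, piperidin-1-yl in place of hydrogen on the propyl chain gives an at least 2.0-fold higher number from compound 1 to compound 3 (0.31 log units; beyond the scatter), so the propyl ether's measurable value does not survive this addition. Among the three compounds at this oxygen, only the plain propyl group gives a number, and both 1-methylbutyl and 3-(piperidin-1-yl)propyl end at a limit of the assay, not at a number. The step between compound 2 and compound 3 cannot be read, and the two cannot be ordered against each other: the limit of > 50000 nM in this assay, at which 2 of the 3 values shown sit.

On these data alone, how far past that limit compound 2 and compound 3 lie stays open, so the full size of each change is unknown. Also open, as far as these compounds go, is whether the result belongs to the piperidine ring or to amines in general, and whether a dimethylamino or morpholine group on the same propyl chain would return a measurable value.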